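Working notes: shortening the hydroxycarbamoyl chain

The compounds below may be only part of what the source reports. "The series", "measured", "known", "first", "only" and "open" are said of these compounds alone.

In a functional assay on NCI-H1975 cells (Homo sapiens) for antiproliferative activity, read by MTT assay, with a stated time of 72 h (on this read-out higher numbers stand for weaker inhibition and lower numbers for stronger inhibition), compound 2 `C=CC(=O)Nc1cc2c(Nc3ccc(OCc4cccc(F)c4)c(Cl)c3)ncnc2cc1OCc1cn(CCCCC(=O)NO)nn1` gives 14500 nM and sits at the high end of the numbers, level within the scatter with compound 1 `C=CC(=O)Nc1cc2c(Nc3ccc(OCc4cccc(F)c4)c(Cl)c3)ncnc2cc1OCc1cn(CCCC(=O)NO)nn1` (12000 nM). A change away from the chain leads from compound 2 to compound 3 `C=CC(=O)Nc1cc2c(Nc3cccc(Cl)c3F)ncnc2cc1OCc1cn(CCCCC(=O)NO)nn1`, which shows a lower number (4180 nM), beyond the scatter.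

Compound 4 `C=CC(=O)Nc1cc2c(Nc3ccc(OCc4cccc(F)c4)c(Cl)c3)ncnc2cc1OCc1cn(CCC(=O)NO)nn1` has hydroxycarbamoyl in place of 2-(hydroxycarbamoyl)ethyl on a saturated chain carbon, two bonds along the chain from an aromatic nitrogen. The 4-(hydroxycarbamoyl)butyl of compound 2 thus becomes 2-(hydroxycarbamoyl)ethyl.

Among the compounds with values here, the only measured step along this chain joins the 3-(hydroxycarbamoyl)propyl of compound 1 to the butyl chain (a 1.2-fold higher number from compound 1 to compound 2 (0.08 log units; within the scatter)), and it stays within the scatter. Within the data shown here, no measurement yet covers a chain as short as that of compound 4, so the range is kept wide. No step beyond the scatter is expected in this assay, the expected change being (a 1.2-fold lower number from compound 2 to compound 4 (0.08 log units; within the scatter)). For compound 4 the estimated value is 12000 nM with a range from 5500 nM to 26000 nM as the expected span.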

Compound 4, half-maximal inhibitory concentration: 21000 nM
Compound 4: middle estimate off by 1.8-fold (0.24 log units), on the low side; measured number inside the range.
By their numbers in this assay, from the lowest: compound 3; then compounds 1, 2 and 4 (each within the scatter of the next).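

In this assay, the step to the shortest chain here, 2-(hydroxycarbamoyl)ethyl, stays within the scatter, both from the butyl chain (a 1.4-fold higher number from compound 2 to compound 4 (0.16 log units; within the scatter)) and from the propyl chain (a 1.8-fold higher number from compound 1 to compound 4 (0.24 log units; within the scatter)). On the core of compound 2, the 2-(hydroxycarbamoyl)ethyl, 3-(hydroxycarbamoyl)propyl and 4-(hydroxycarbamoyl)butyl chains therefore read as level at this position, and none of the chain changes shown separates beyond the scatter. No outside evidence bears on this result.

It remains open whether the same chains stay level on the core of compound 3, shown here with 4-(hydroxycarbamoyl)butyl at 4180 nM in this assay. From the compounds shown here alone, it is equally open whether a longer chain, or a carboxylic acid in place of the hydroxycarbamoyl end, would move the number beyond the scatter.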